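The compounds below may be only part of what the source reports. "The series", "measured", "known", "first", "only" and "open" are said of these compounds alone.

The series shares one core; compound 1 `COc1cc(-c2cc(/C=C/C(=O)c3ccc(Cl)c(Cl)c3)[nH]n2)cc(OC)c1OC` carries a 3,4-dichlorophenyl on the carbonyl carbon, and in a functional assay on Hs-578T cells (Homo sapiens) for cytotoxicity, read by sulforhodamine B assay, with a stated time of 48 h, tested at 0.1 uM (on this read-out lower numbers stand for a stronger effect and higher numbers for a weaker effect at the one concentration tested), compound 1 gives 105%. Compound 2 `COc1ccc(C(=O)/C=C/c2cc(-c3cc(OC)c(OC)c(OC)c3)n[nH]2)cc1OC` gives 99% in this assay. Compound 2 stands lowest of the two numbers, with compound 1 the nearest, and the move a number 6 percentage points lower from compound 1 to compound 2 (within the scatter) leaves the pair inseparable on this read-out.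

Compound 3 `COc1cc(-c2cc(/C=C/C(=O)c3ccc(F)c(F)c3)[nH]n2)cc(OC)c1OC` differs from compound 2 at the same carbonyl carbon: 3,4-difluorophenyl in place of 3,4-dimethoxyphenyl on a carbonyl carbon. For the measured compounds named here, the only measured step that bears on this position is a number 6 percentage points lower from compound 1 to compound 2 (within the scatter), where 3,4-dichlorophenyl and 3,4-dimethoxyphenyl gave numbers that cannot be told apart; no third group at this place has been measured. A step within the scatter is expected here: a number 3 percentage points higher from compound 2 to compound 3 (within the scatter). Compound 3 is estimated at 102% in this assay, with a range from 90% to 112%.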

Compound 3, a percentage reported as activity, at one concentration (the size of the read-out at that concentration, not a potency): 97%
The estimate for compound 3 lay 5 percentage points above the measured number; the range from low to high includes it.
By their numbers in this assay, from the lowest: compounds 3, 2 and 1 (each within the scatter of the next).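

On the carbonyl carbon, 3,4-difluorophenyl joins 3,4-dichlorophenyl and 3,4-dimethoxyphenyl, and in this assay the result is a number 2 percentage points lower from compound 2 to compound 3 (within the scatter) and a number 8 percentage points lower from compound 1 to compound 3 (within the scatter), so the three groups cannot be told apart at the one concentration tested. The 3,4-difluorophenyl counts 0 hydrogen-bond acceptors against 2 for 3,4-dimethoxyphenyl, and this exchange still leaves compound 2 and compound 3 inseparable on this read-out. Nothing at hand offers an explanation for these numbers.

Going by these compounds, it remains open whether any group at this place can move the number beyond the scatter. An aminophenyl, a carboxyphenyl or an unsubstituted phenyl on the carbonyl carbon would test this, and whether the three compounds stay together at other concentrations is also unresolved.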